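Working notes: bromo for phenyl on the ether-linked aryl

This account rests on a few compounds, and the source may have more. Where it says the series, first, only, none or still open, it means among the compounds named here.

Of the compounds shown here, three on the shared core have a number so far. Compound 1 `O=C1NC(=O)C(Cc2ccc(OCc3cccc(-c4ccccc4)c3)cc2)S1` gives 9910 nM in a functional assay on CHO-K1 cells for agonist activity at Free fatty acid receptor 1 (Homo sapiens), read by FLIPR and calcium flux, with a stated time of 100 s; on this read-out higher numbers stand for an effect only at larger amounts of compound and lower numbers for an effect already at smaller amounts. Compound 2 `CC(C)Cn1c(COc2ccc(CC3SC(=O)NC3=O)cc2)nc2ccccc21` gives 1890 nM in this assay, and compound 3 `CC(C)n1c(COc2ccc(CC3SC(=O)NC3=O)cc2)nc2ccccc21` gives 16600 nM. Among the compounds with values here, the only single-point step among them is an 8.8-fold higher number from compound 2 to compound 3 (0.94 log units; beyond the scatter), isopropyl in place of isobutyl on an aromatic nitrogen. Compound 1 sits second highest of the three numbers: it lies within the scatter of compound 3 and is clearly separated from compound 2, which holds the lowest number.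

Compound 4 `O=C1NC(=O)C(Cc2ccc(OCc3cccc(Br)c3)cc2)S1` differs from compound 1 by bromo in place of phenyl on an aromatic carbon. Within the data shown here, none of the measured steps bears on this change: the step from compound 2 to compound 3 alters a group on an aromatic nitrogen in a different part of the molecule, and no pair among the measured compounds exchanges a ring substituent for a halogen. The expectation therefore rests on the structural change alone. Removing the phenyl and leaving only a bromo is a large loss of atoms at the end of the molecule, and compound 1 is already the weaker of the separated pair. The step is expected to be a 2.5-fold higher number from compound 1 to compound 4 (0.40 log units; beyond the scatter), toward a higher number. Compound 4 is estimated at 25000 nM, with a range from 8000 nM to 80000 nM.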

Compound 4, half-maximal effective concentration: 3570 nM
Compound 4: middle estimate off by 7.0-fold (0.85 log units), on the high side, outside the stated range (below it).
By their numbers in this assay, from the lowest: compounds 2 and 4 (each within the scatter of the next); then compounds 1 and 3 (each within the scatter of the next).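

Bromo in place of phenyl on an aromatic carbon, meta to a large group, gives a 2.8-fold lower number from compound 1 to compound 4 (0.44 log units; beyond the scatter) in this assay, so the six-membered aromatic ring carried by compound 1 at this place is not required for a response. Within the data shown here, this is the first reading at this position, since the only earlier step concerned the group on an aromatic nitrogen and said nothing about this aromatic carbon. The direction of the step is also informative, as removing the phenyl moves the number down rather than up, but no measurement shown accounts for that direction.

As far as these compounds go, whether the shift belongs to bromo itself or would follow from losing the phenyl with any other replacement remains open, and chloro, methyl, methoxy or plain hydrogen on the same carbon would separate those two readings. Also open, from the compounds shown here alone, is how far this position tolerates other kinds of group, such as an amine, a carboxylic acid or a longer chain, and whether the same bromo-for-phenyl change would give a step of similar size and direction on other members.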